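This account rests on a few compounds, and the source may have more. Where it says the series, first, only, none or still open, it means among the compounds named here.

Measured in an ADME assay on HepG2 cells (Homo sapiens) for cytotoxicity; a lower number here means that less compound is tolerated, a higher number that more compound is tolerated:

- Compound 1 `COCC#Cc1cc2ncnc(Nc3ccc(OCc4cccc(F)c4)c(Cl)c3)c2s1`: > 33 uM, a limit
- Compound 2 `CC(C)(C)OC(=O)N1CCC[C@H]1C#Cc1cc2ncnc(Nc3ccc(OCc4cccc(F)c4)c(Cl)c3)c2s1`: > 26 uM, a limit
- Compound 3 `CN1CCN(CC#Cc2cc3c(Nc4ccc(OCc5cccc(F)c5)c(Cl)c4)ncnc3s2)CC1`: 15 uM

Among these three compounds, only compound 3 has a measured number, 15 uM. The other two results are limits, so compound 3 cannot be ranked against either of them.

The next compound to be tested in this assay is compound 4 `CCCN(CC#Cc1cc2c(Nc3ccc(OCc4cccc(F)c4)c(Cl)c3)ncnc2s1)CCC`. The structural change from compound 3 is dipropylamino in place of 4-methylpiperazin-1-yl on a saturated chain carbon bound to a triple-bonded carbon. Put simply, dipropylamino stands in place of 4-methylpiperazin-1-yl on a saturated chain carbon bound to a triple-bonded carbon.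

Going by the values given here, only one measured step bears on this change, and it offers little guidance. a step that the two limits leave unreadable from compound 1 to compound 2 also alters a group on a triple-bonded carbon, but it has no readable size and therefore sets no scale. Among the compounds with values here, no measured step exchanges one amine for another. The expectation must therefore rest on the value of compound 3, 15 uM, with a wide margin on either side.

The expected change is a 1.2-fold lower number from compound 3 to compound 4 (0.06 log units; within the scatter), with no shift beyond the usual scatter and no direction favoured. For compound 4, the estimated value is 13 uM, with an expected range of 6 uM to 30 uM.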

Compound 4, half-maximal toxic concentration: 17 uM
Beside the measured number, compound 4's estimate is 1.3-fold (0.12 log units) below it; the measured number falls inside the stated range.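

In this assay, going by these compounds alone, the exchange of 4-methylpiperazin-1-yl for dipropylamino on a saturated chain carbon bound to a triple-bonded carbon gives the first readable step at this place: a 1.1-fold higher number from compound 3 to compound 4 (0.05 log units; within the scatter). The two groups have the same count of heavy atoms, yet they differ in that dipropylamino has no ring and one nitrogen fewer, so this pair shows that an open-chain amine can stand in for the ring amine with no change in the read-out beyond the scatter. None of the measurements shown gives a reason for this result.

The results of compound 1 and compound 2 are both limits and the step between them cannot be read, so the pair of compound 3 and compound 4 alone speaks to this place, and it covers only two tertiary amines. Open, as far as these compounds go, is whether a primary amine, a morpholine ring, a carboxylic acid or a much longer alkyl chain on the same saturated chain carbon would also stay within the scatter of these two compounds, or would move the number in either direction.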